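A few compounds are considered here, and "the series" means these few. Any claim that something is new, unique, unknown or untested is made for them only; others in the source may bear on it.

Measured so far in an ADME assay on MT4 cells (Homo sapiens) for cytotoxicity, read by MTT assay; a lower number here means that less compound is tolerated, a higher number that more compound is tolerated:
- compound 1 `O=C(CSc1nc(Cc2c(F)cccc2F)cc(=O)[nH]1)c1ccc(Cl)cc1`: > 61000 nM
- compound 2 `Cc1c(Cc2c(F)cccc2F)nc(SCc2ccccc2)[nH]c1=O`: > 70000 nM
- compound 3 `Cc1c(Cc2c(F)cccc2F)nc(SCc2ccc([N+](=O)[O-])cc2)[nH]c1=O`: > 37000 nM

All three entries are limits, not numbers, so no ranking can be drawn among these compounds. Compound 3 has only the limit > 37000 nM in this assay.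

The next compound is compound 4 `Cc1cc(C)cc(CSc2nc(Cc3c(F)cccc3F)c(C)c(=O)[nH]2)c1`. It departs from compound 3 by 3,5-dimethylphenyl in place of 4-nitrophenyl on a saturated chain carbon bound to a sulfur.

Among the measured compounds shown here, only one measured step bears on this change, since it also alters the same aromatic ring: a step that the two limits leave unreadable from compound 2 to compound 3. That step gives no size to carry over. Compound 2, which has an unsubstituted phenyl there, has the limit > 70000 nM. Compound 1 differs more widely from compound 4. Compound 1 has the limit > 61000 nM.

With no readable step behind it, no shift beyond the usual scatter is expected in either direction, and compound 4 may well return only a limit too. The expected step is a step that the limit leaves unreadable from compound 3 to compound 4. For compound 4 the estimated value is 50000 nM, with an expected range from 15000 nM to 90000 nM.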

Compound 4, half-maximal cytotoxic concentration: > 65000 nM
Compound 4 ended at the assay's limit; the forecaster's own chance of this, stated with the estimate: 75%; middle value at least 1.3-fold (0.11 log units) away from the limit.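

In this assay compound 4 gives > 65000 nM, which is a limit and not a number. Compound 2 and compound 3 also carry only limits, and neither step to compound 4 can be read. The compounds shown leave open at what concentration any of them becomes cytotoxic, and whether swapping the groups on the aromatic ring changes that concentration.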